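A few compounds are considered here, and "the series" means these few. Any claim that something is new, unique, unknown or untested is made for them only; others in the source may bear on it.

For the measured compounds named here, in a functional assay on NCI-H460 cells (Homo sapiens) for cytotoxicity, read by MTT assay (a higher number here means a weaker inhibitor, a lower number a stronger inhibitor), compound 2 `COc1cc(/C=C/C(=O)c2sc(Nc3ccc(F)c(Cl)c3)nc2C)cc(OC)c1OC` gives 6310 nM, the only number in this set. The other value is a limit. It belongs to compound 1 `COc1cc(/C=C/C(=O)c2sc(Nc3cccc(Cl)c3)nc2C)cc(OC)c1OC`: in this assay compound 1 gives > 25000 nM, a limit of the assay and not a number. Going by the values given here, the single measured step, an at least 3.9-fold lower number from compound 1 to compound 2 (0.59 log units; beyond the scatter), rests on (the limit of > 25000 nM in this assay, at which 1 of the 2 values shown sits), so its size is only a bound. On these data alone, compound 3 `COc1cc(/C=C/C(=O)c2sc(Nc3ccccc3)nc2C)cc(OC)c1OC` is untested; it differs from compound 2 by phenyl in place of 3-chloro-4-fluorophenyl on a nitrogen on an aromatic ring. Since that fluoro is now removed, along with the chloro, the expected step of a 3.2-fold higher number from compound 2 to compound 3 (0.50 log units; beyond the scatter) points to a higher number. Compound 3 is estimated at 20000 nM, within 5000 nM to 50000 nM.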

Compound 3, half-maximal inhibitory concentration: > 25000 nM
Compound 3 ended at the assay's limit; the forecaster's own chance of this, stated with the estimate: 45%; middle value at least 1.2-fold (0.09 log units) from the limit.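

On a nitrogen on an aromatic ring, phenyl in place of 3-chloro-4-fluorophenyl gives an at least 3.9-fold higher number from compound 2 to compound 3 (0.59 log units; beyond the scatter) in this assay. Compound 3 thus sits at the same limit as compound 1, and of the three compounds only compound 2, which carries both halogens, keeps a number. The step between compound 1 and compound 3 cannot be read, and the step to compound 3 is only a bound: the limit of > 25000 nM in this assay, at which 2 of the 3 values shown sit.

On these data alone, what a 4-fluorophenyl, a 4-methoxyphenyl or a 4-carboxyphenyl would give on that nitrogen stays open. So does the true size of the step.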